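Notes on the methoxy-to-hydroxy step in the pyrazole series

The source may hold more compounds than are shown below. What is called first, only, known or untested is meant among the compounds shown, and "the series" means these compounds.

Measured so far in a functional assay on SF-295 cells (Homo sapiens) for cytotoxicity, read by sulforhodamine B assay, with a stated time of 48 h, tested at 100 nM; a higher number here means a weaker effect of the compound at the concentration tested, a lower number a stronger effect:
- compound 1 `COc1cc(C)cc(-c2nn(CC#N)cc2-c2ccc(-c3cccc(C(C)=O)c3)nc2)c1` gives 75%
- compound 2 `Cc1cc(O)cc(-c2nn(CC#N)cc2-c2ccnc(-c3ccc(Oc4ccccc4)cc3)c2)c1` gives 87%
- compound 3 `COc1cc(C)cc(-c2nn(CC#N)cc2-c2ccnc(-c3ccc(N(C)C)cc3)c2)c1` gives 3%

Compound 3 stands lowest of the three numbers, and both gaps lie beyond the scatter: its nearest neighbour is compound 1, whose number is higher by a margin well outside repeat variation, and the furthest is compound 2. Within the data shown here, compounds 1 and 2 differ from compound 3 in more than one place, so their numbers show only that the dimethylaminophenyl-bearing compound 3 sits far apart from the other two; no single cause can be read from them.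

Compound 4 `Cc1cc(O)cc(-c2nn(CC#N)cc2-c2ccnc(-c3ccc(N(C)C)cc3)c2)c1` has not been measured in this assay. It differs from compound 3 by hydrogen in place of methyl on an oxygen on an aromatic ring, that is, methoxy to hydroxy on the aryl ring attached to the shared core. Among the measured compounds shown here, no measured pair isolates this change. Compound 2 carries the hydroxy group yet has the highest number, but its other aryl differs as well, so it does not settle the matter.

The step is expected to be modest and, if anything, toward a higher number: a number 17 percentage points higher from compound 3 to compound 4 (beyond the scatter). Compound 4 is estimated at 20%, with a range from 3% to 60%.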

Compound 4, a percentage reported as activity, at one concentration (the size of the read-out at that concentration, not a potency): 78%
The estimate for compound 4 lay 58 percentage points below the measured number; measured number above the stated range.
By their numbers in this assay, from the lowest: compound 3; then compounds 1, 4 and 2 (each within the scatter of the next, the first and the last beyond it).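

In this assay, among these compounds, this is the first pair that isolates the change, and hydrogen in place of methyl on the oxygen gives a number 75 percentage points higher from compound 3 to compound 4 (beyond the scatter). With the dimethylamino group held constant, the methoxy of the 3-methoxy-5-methylphenyl therefore cannot be exchanged for hydroxy without losing nearly all of the effect seen at the tested concentration. With the hydroxy group held constant, dimethylamino in place of phenoxy gives a number 9 percentage points lower from compound 2 to compound 4 (within the scatter), so the two hydroxy compounds cannot be told apart here and the dimethylamino group alone does not carry the low number of compound 3; nothing at hand accounts for the size of the methoxy-to-hydroxy step.

The compounds shown leave open whether the same step appears with the phenoxy group, as compound 2 has no methoxy partner among them. They also leave open how narrowly the effect depends on the methyl on the oxygen, a question that an ethoxy group or an amine in the same place on the aryl ring would help to separate.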